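Dimethylamino in Place of Acetyl: Expected Cell Readout

This account rests on a few compounds, and the source may have more. Where it says the series, first, only, none or still open, it means among the compounds named here.

Compound 1, `COc1cc(C)cc(-c2c(-c3ccnc(-c4ccc(C(C)=O)cc4)c3)cnn2CC#N)c1`: 96%
Compound 2, `COc1cc(C)cc(-c2nn(CC#N)cc2-c2ccc(-c3cccc(C(C)=O)c3)nc2)c1`: 99%
Compound 3, `COc1cc(C)cc(-c2nn(CC#N)cc2-c2ccnc(-c3ccc(N(C)C)cc3)c2)c1`: 105%

Of the compounds shown here, three have been measured in a functional assay on BT-549 cells (Homo sapiens) for cytotoxicity, read by sulforhodamine B assay, with a stated time of 48 h, tested at 0.001 uM; a lower number here means a stronger effect, a higher number a weaker effect of the compound at the concentration tested. In this assay compound 1 gives 96%, the lowest of the three numbers, but compound 2 and compound 3 both lie within the usual scatter of it, so no order among the three can be read from these values. For the measured compounds named here, no pair of measured compounds differs in only one place, so no measured single step is available.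

Compound 4, `COc1cc(C)cc(-c2c(-c3ccnc(-c4ccc(N(C)C)cc4)c3)cnn2CC#N)c1`, differs from compound 1 in one place: dimethylamino in place of acetyl on an aromatic carbon. Compound 3 already carries a dimethylamino group on a differently arranged core and sits in the same band as compound 1 and compound 2 in this assay, which gives no sign that this group moves the readout. The step is therefore expected to be none beyond the scatter, estimated as a number 5 percentage points higher from compound 1 to compound 4 (within the scatter). Compound 4 is expected to give 101% in this assay, within a range from 90% to 112%.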

Compound 4, a percentage reported as activity, at one concentration (the size of the read-out at that concentration, not a potency): 93%
Estimate against measurement, compound 4: 8 percentage points above; low and high end bracket the measured number.
By their numbers in this assay, from the lowest: compounds 4, 1, 2 and 3 (each within the scatter of the next, the first and the last beyond it).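

With dimethylamino in place of acetyl on the shared core, the readout shows a number 3 percentage points lower from compound 1 to compound 4 (within the scatter) in this assay at the single concentration tested. For the compounds shown here, this is the first direct reading of a change at this position, para to a large group, where compound 3 could offer only an indirect hint from a differently arranged core. On this core, the 4-acetylphenyl to 4-(dimethylamino)phenyl change does not separate the two compounds in this readout, and nothing shown bears on a cause for that result.

As far as these compounds go, it remains open whether a carboxylic acid, a primary amine or a longer alkyl chain at this position would give a different readout. The compounds shown also leave open whether compound 1 and compound 4 would stay together at higher concentrations.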